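A longer chain on the shared core of compound 1

The compounds below may be only part of what the source reports. "The series", "measured", "known", "first", "only" and "open" are said of these compounds alone.

Compound 1 `CCCc1ccc(NC(=O)N[C@H](C)c2ccccc2)cc1` gives 35% in an ADME assay on the whole organism with Oryza sativa as the target, tested at 10 uM; a higher number here means a weaker effect of the compound at the concentration tested, a lower number a stronger effect.
Compound 2 `CCCc1ccc(NC(=O)N[C@@H](C)c2ccccc2)cc1` gives 73% in this assay.
Compound 3 `C[C@H](NC(=O)Nc1ccc(C(C)(C)C)cc1)c1ccccc1` gives 64% in this assay.

Compound 1 holds the lowest of the three numbers in this assay, with compound 3 nearest to it and compound 2 furthest away. The step of a number 38 percentage points higher from compound 1 to compound 2 (beyond the scatter) is large, and it rests on (the fact that compounds 1 and 2 differ only in the configuration as drawn). The step of a number 9 percentage points lower from compound 2 to compound 3 (within the scatter), tert-butyl in place of propyl on an aromatic carbon, stays within the scatter.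

Compound 4 `CCCCCc1ccc(NC(=O)N[C@H](C)c2ccccc2)cc1` differs from compound 1 by ethyl in place of hydrogen on a saturated chain carbon, three bonds along the chain from an aromatic carbon. The configuration step does not bear on this change. Going by the values given here, the only step that touches the chain on the aromatic carbon is the one within the scatter, so the account expects no step beyond the scatter in this assay, that is a number 3 percentage points higher from compound 1 to compound 4 (within the scatter). For compound 4 the estimate in this assay is therefore 38%, expected to lie between 20% and 60%.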

Compound 4, a percentage reported as activity, at one concentration (the size of the read-out at that concentration, not a potency): 97%
Beside the measured number, compound 4's estimate is 59 percentage points below it; measured number outside the range, above it.
By their numbers in this assay, from the lowest: compound 1; then compounds 3 and 2 (each within the scatter of the next); then compound 4.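

In this assay the change from propyl to pentyl on the core of compound 1 gives a number 62 percentage points higher from compound 1 to compound 4 (beyond the scatter) and so moves the number towards a weaker effect at the concentration tested. The earlier change on this chain, a number 9 percentage points lower from compound 2 to compound 3 (within the scatter), did not show that the chain could matter this much; the new step shows that the read-out responds strongly to added length at this place, at least with the configuration drawn in compound 1. The configuration step does not bear on this change, and nothing else shown gives a reason for it.

The compounds shown leave open whether butyl would fall nearer to propyl or to pentyl, and whether a longer chain or an amine at the chain end would follow the same course. They also leave open whether pentyl with the opposite drawn configuration would show the same configuration step as propyl.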